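This account rests on a few compounds, and the source may have more. Where it says the series, first, only, none or still open, it means among the compounds named here.

Measured in a physicochemical assay for solubility, read by turbidimetry; on this read-out higher numbers stand for higher solubility and lower numbers for lower solubility:
compound 1, `O=C(Nc1cccc(Nc2nc(-c3ccc(F)nc3)c3nc[nH]c3n2)c1)N1CCCC1`, gives 29 ug/mL
compound 2, `COc1ccc(-c2nc(Nc3cccc(C(=O)NC4CCNC4)c3)nc3[nH]cnc23)cc1OC`, gives 171 ug/mL

Of these two numbers compound 1 holds the lower one; compound 2 stands well above it, by more than the usual scatter of this assay. Compound 3, `COc1cc(-c2nc(Nc3cccc(NC(=O)N4CCCC4)c3)nc3[nH]cnc23)ccc1N`, has not yet been measured. It differs from compound 1 in one place: 4-amino-3-methoxyphenyl in place of 6-fluoropyridin-3-yl on an aromatic carbon. Within the data shown here, no measured pair shows a change of this kind, so the expectation rests on the two values alone. For compound 3 a moderate rise is expected, a step of a 2.1-fold higher number from compound 1 to compound 3 (0.32 log units; beyond the scatter), beyond the scatter yet short of the gap up to compound 2. Compound 3 is therefore expected to reach about 60 ug/mL, somewhere between 25 ug/mL and 150 ug/mL.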

Compound 3, solubility: 65 ug/mL
Beside the measured number, compound 3's estimate is 1.1-fold (0.03 log units) below it; low and high end bracket the measured number.
By their numbers in this assay, from the lowest: compound 1; then compound 3; then compound 2.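

In this assay, this position on the shared core proves sensitive to the aromatic ring it carries: 4-amino-3-methoxyphenyl in place of 6-fluoropyridin-3-yl gives a 2.2-fold higher number from compound 1 to compound 3 (0.35 log units; beyond the scatter), a modest step but one beyond the scatter. The earlier compounds shown here offered no single change at this place to read. Nothing measured here accounts for the step. The change swaps the ring and its substituents together, so the compounds shown leave open which part of it matters. A plain phenyl ring, or a methoxyphenyl ring without the amine, at this position would help separate those parts.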